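The compounds below may be only part of what the source reports. "The series", "measured", "known", "first", "only" and "open" are said of these compounds alone.

Compound 2 `COc1cc2c(Oc3ccc(NC(=O)N/N=C/c4ccc(O)cc4)cc3F)ccnc2cc1OCCCN1CCCCC1` is one of three close analogues that have been measured in a functional assay on MKN-45 cells (Homo sapiens) for cytotoxicity, read by MTT assay, with a stated time of 72 h; a higher number here means a weaker inhibitor, a lower number a stronger inhibitor. Compound 2 gives 850 nM, the highest of the three numbers, but the other two lie close: compound 1 `COc1cc2c(Oc3ccc(NC(=O)N/N=C/c4ccc(C(F)(F)F)cc4)cc3F)ccnc2cc1OCCCN1CCCCC1` gives 630 nM and compound 3 `C=CCc1cccc(/C=N/NC(=O)Nc2ccc(Oc3ccnc4cc(OCCCN5CCCCC5)c(OC)cc34)c(F)c2)c1OC` gives 670 nM. The step of a 1.3-fold higher number from compound 1 to compound 2 (0.13 log units; within the scatter) and the step of a 1.3-fold lower number from compound 2 to compound 3 (0.10 log units; within the scatter) both stay within the scatter, as does the step of a 1.1-fold higher number from compound 1 to compound 3 (0.03 log units; within the scatter), so the three numbers cannot be placed in any order.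

Compound 4 `COc1cc2c(Oc3ccc(NC(=S)N/N=C/c4ccc(Cl)cc4)cc3F)ccnc2cc1OCCCN1CCCCC1` is a further analogue. Relative to compound 2 the change is a group of 12 heavy atoms (8 carbon, 2 nitrogen, 1 sulfur, 1 chlorine; one six-membered aromatic ring of carbon only) in place of a group of 12 heavy atoms (8 carbon, 2 nitrogen, 2 oxygen; one six-membered aromatic ring of carbon only), on a nitrogen on an aromatic ring. Among the measured compounds shown here, no measured step exchanges the carbonyl for a thiocarbonyl, so that part of the change is untested. The measured steps that bear on the rest are those that swap the aryl group at the end of the chain, and the step of a 1.3-fold higher number from compound 1 to compound 2 (0.13 log units; within the scatter) together with the step of a 1.3-fold lower number from compound 2 to compound 3 (0.10 log units; within the scatter) shows that such swaps moved this assay by less than the scatter. The expectation for compound 4 is therefore a step of a 1.2-fold lower number from compound 2 to compound 4 (0.08 log units; within the scatter), no larger than the scatter, in no particular direction. Compound 4 is estimated at 700 nM, with a range from 280 nM to 1800 nM.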

Compound 4, half-maximal inhibitory concentration: 500 nM
The estimate for compound 4 lay 1.4-fold (0.15 log units) above the measured number; the range from low to high includes it.
By their numbers in this assay, from the lowest: compounds 4, 1, 3 and 2 (each within the scatter of the next).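

In this assay, replacing the carbonyl with a thiocarbonyl while chlorine takes the place of the hydroxy on the aromatic ring gives a 1.7-fold lower number from compound 2 to compound 4 (0.23 log units; within the scatter) and so stays within the scatter. Among the compounds shown here, until now, the group on a nitrogen on an aromatic ring had varied only at the aryl end, so this is the first sign that the link itself can carry sulfur in place of oxygen without a change that can be read, at least when the chlorine comes with it. The step joins two changes in one and could hide opposing contributions, and no measurement available here accounts for the result.

As far as these compounds go, it remains open what the sulfur and the chlorine each do alone, which a thiocarbonyl paired with the hydroxy, or a carbonyl paired with the chlorine, would separate. Also open, from the compounds shown here alone, is whether a group such as an amine or a carboxylic acid on that aromatic ring, or a longer chain in place of the link to it, would produce a step beyond the scatter.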